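The source may report more compounds than this note shows. Statements on the series, on what has been measured and on what is new or still open speak of the compounds shown alone.

Working notes on the series, all read in a physicochemical assay for solubility, measured as kinetic solubility, at pH 2; a lower number here means a less soluble compound, a higher number a more soluble compound. Compound 1 `CC(C)C(CC1C(=O)NC(=O)N1C)c1ccc(-c2ccc3cccc(F)c3c2)[nH]c1=O` gives 26600 nM and stands level, within the scatter, with the two other measured compounds. Compound 3 `CC(C)[C@H](C[C@H]1OC(=O)NC1=O)c1ccc(-c2ccc3cccc(F)c3c2)[nH]c1=O` gives 24400 nM, and compound 2 `CCC(/C=C1\OC(=O)NC1=O)(CC)c1ccc(-c2ccc3cccc(F)c3c2)[nH]c1=O` gives 13500 nM. These three values span no more than the usual scatter, although the groups on the chain differ.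

The next compound to read is compound 4 `CC(C)C(/C=C1\SC(=O)NC1=O)c1ccc(-c2ccc3cccc(F)c3c2)[nH]c1=O`, still unmeasured. Its change from compound 1 is a group of 8 heavy atoms (4 carbon, 1 nitrogen, 2 oxygen, 1 sulfur; one five-membered non-aromatic ring with 2 hetero atoms) in place of a group of 9 heavy atoms (5 carbon, 2 nitrogen, 2 oxygen; one five-membered non-aromatic ring with 2 hetero atoms), on a saturated chain carbon bound to an aromatic carbon and a saturated chain carbon. For the measured compounds named here, no two measured compounds differ in one place only, so the data hold no direct measure of such a swap. The expectation leans on compound 2, whose five-membered ring is also joined through a double bond outside the ring, at 13500 nM. The estimated step of a 2.2-fold lower number from compound 1 to compound 4 (0.35 log units; beyond the scatter) points downward and is expected to be modest, about the edge of the scatter. For compound 4 the estimated value is 12000 nM, with an expected range of 4000 nM to 27000 nM.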

Compound 4, solubility: 4800 nM
Compound 4: the middle estimate sits 2.5-fold (0.40 log units) above what was measured, within the range that was stated.
By their numbers in this assay, from the lowest: compound 4; then compounds 2, 3 and 1 (each within the scatter of the next).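

In this assay, for the compounds shown here, this is the first step that can be read at a single place: on a saturated chain carbon bound to an aromatic carbon and a saturated chain carbon, replacing the (3-methyl-2,5-dioxoimidazolidin-4-yl)methyl group with the sulfur-containing group of compound 4 gives a 5.5-fold lower number from compound 1 to compound 4 (0.74 log units; beyond the scatter). Going by these compounds alone, the reading at this position therefore responds to the group it carries, something the earlier compounds, level within the scatter and with no single-place pair among them, could not show. No measurement at hand explains this step.

The step belongs to the whole group, and no single-place pair shown separates the ring sulfur from the double bond outside the ring. On these data alone, how an amine or a carboxylic acid at this position would read also remains open.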